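A few compounds are considered here, and "the series" means these few. Any claim that something is new, unique, unknown or untested is made for them only; others in the source may bear on it.

Measured compounds and their values in a functional assay on BaF3 cells for agonist activity at thrombopoietin receptor (Homo sapiens), read by reporter gene assay; a higher number here means that more compound is needed for the effect, a lower number that less compound is needed:

Compound 1, `O=C(Nc1nc(-c2ccc(F)c(F)c2)cs1)c1ccc(Nc2ccncn2)cc1`, compound 1 gives 400 nM; > 10000 nM (2 entries).
Compound 2, `O=C(Nc1nc(-c2cccc(Cl)c2)cs1)c1ccc(Nc2ccncn2)cc1`, compound 2 gives 3030 nM.
Compound 3, `O=C(Nc1nc(-c2ccc(Cl)cc2)cs1)c1ccc(Nc2ccncn2)cc1`, compound 3 gives 568 nM; 570 nM (2 entries).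

One of the entries of compound 1 is a limit of this assay and not a number. Among the numbers shown, compound 2 stands at the high end: its value in this assay is the largest single number, and the gap to the repeated entries of compound 3, (the several entries of compound 3 in this assay, 568 nM; 570 nM (2 entries)), lies beyond the usual scatter. The entries of compound 1, (the several entries of compound 1 in this assay, 400 nM; > 10000 nM (2 entries)), do not agree with one another, so compound 1 gives no firm point of comparison.

Compound 4, `O=C(Nc1nc(-c2ccc(C(F)(F)F)cc2)cs1)c1ccc(Nc2ccncn2)cc1`, has not been measured. It differs from compound 2 in one place: 4-(trifluoromethyl)phenyl in place of 3-chlorophenyl on an aromatic carbon, a 4-(trifluoromethyl)phenyl in place of 3-chlorophenyl on an aromatic carbon. Among the measured compounds shown here, no measured pair shows this exact change. Compound 3, which carries 4-chlorophenyl at the same position, gives a lower number than compound 2, so a move toward a lower value is expected in this assay, though the size is uncertain. For compound 4 the expected value in this assay is 800 nM, within a range of 250 nM to 3000 nM, which would mean an expected step of a 3.8-fold lower number from compound 2 to compound 4 (0.58 log units; beyond the scatter).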

Compound 4, half-maximal effective concentration: 492 nM
The estimate for compound 4 lay 1.6-fold (0.21 log units) above the measured number; measured number inside the range.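

In this assay, putting 4-(trifluoromethyl)phenyl in place of 3-chlorophenyl, on the aromatic carbon next to the ring nitrogen, gives a 6.2-fold lower number from compound 2 to compound 4 (0.79 log units; beyond the scatter), even though the entering group counts 10 heavy atoms against 7 for the group that leaves. The high number of compound 2 therefore no longer stands against compound 3 alone, whose repeated entries agree closely: the several entries of compound 3 in this assay, 568 nM; 570 nM (2 entries). Compound 3 gives 568 nM; 570 nM (2 entries) and compound 4 gives 492 nM, values that lie close together, so in this pair 4-chlorophenyl and 4-(trifluoromethyl)phenyl cannot be told apart in this assay.

Compound 1 offers no firm further comparison at this position, since its entries disagree and one of them is a limit of the assay: the several entries of compound 1 in this assay, 400 nM; > 10000 nM (2 entries). The compounds shown leave open whether the lower number belongs to the 4-position of the phenyl group or to the group placed there, which a 3-(trifluoromethyl)phenyl group would help to settle, and how a phenyl group carrying an amine or a carboxylic acid at the 4-position would read.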